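The source may hold more compounds than are shown below. What is called first, only, known or untested is meant among the compounds shown, and "the series" means these compounds.

Compound 1 `CC(C)n1ncc2c(C(=O)Nc3ccccc3F)cc(-c3cccnc3)nc21`: 50000 nM
Compound 2 `CC(C)n1ccc2c(C(=O)Nc3ccc(F)cc3)cc(-c3cccs3)nc21`: > 200000 nM
Compound 3 `CC(C)n1ncc2c(C(=O)Nc3c(F)cccc3F)cc(-c3cccs3)nc21`: > 200000 nM

These three compounds share a core and were tested in an ADME assay on LLC-MK2 cells (Macaca mulatta) for cytotoxicity, read by spectrophotometry and crystal violet staining, with a stated time of 4 days; a lower number here means that less compound is tolerated, a higher number that more compound is tolerated. Compound 1 gives a measured number. The value of compound 2 is a limit of the assay rather than a number. The value of compound 3 is likewise only a limit, so compound 3 stands at the limit of > 200000 nM in this assay, at which 2 of the 3 values shown sit, with no number of its own. Compound 4 `CC(C)n1ncc2c(C(=O)Nc3ncccn3)cc(-c3cccs3)nc21` has not been measured; it differs from compound 3 by pyrimidin-2-yl in place of 2,6-difluorophenyl on an amide-type nitrogen. Going by the values given here, no step between two measured compounds is available, so the size of the change in this assay must be judged from the values alone. The expected step from compound 3 to compound 4 is a number no higher from compound 3 to compound 4 (the limit leaves the size open), nothing beyond the scatter. Compound 4 is therefore expected to give about 200000 nM, within a range from 60000 nM to 400000 nM, and it may well again be reported only as a limit.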

Compound 4, half-maximal cytotoxic concentration: 75000 nM
Estimate against measurement, compound 4: 2.7-fold (0.43 log units) above; the measured number falls inside the stated range.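

In this assay, the group on the amide-type nitrogen proves enough on its own to move the result, as pyrimidin-2-yl in place of 2,6-difluorophenyl gives an at least 2.6-fold lower number from compound 3 to compound 4 (0.42 log units; beyond the scatter). Going by these compounds alone, this is the only step here between compounds that differ in one place, so the earlier values could not show it. Its full size stays unknown, since compound 3 has only a limit: the limit of > 200000 nM in this assay, at which 2 of the 4 values shown sit.

The compounds shown leave open whether the step follows the loss of the two fluorines or the entry of the ring nitrogens. A pyridin-2-yl or an unsubstituted phenyl at this nitrogen would separate the two.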